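The compounds below may be only part of what the source reports. "The series", "measured", "known", "first", "only" and "open" are said of these compounds alone.

Series notes. The shared core of compound 1 `CCC(C)(C)Cc1c[nH]c(CCc2ccc(-n3ccnn3)cc2)n1` carries a five-membered aromatic group on a six-membered aromatic ring of carbon only, and three variants of that group have been measured in a functional assay on HEK293 cells for agonist activity at Bombesin receptor subtype-3 (Mus musculus), read by luminescence and calcium flux, with a stated time of 10 min; a lower number here means that less compound is needed, a higher number that more compound is needed for the effect. Compound 1 gives 57 nM. Compound 2 `CCC(C)(C)Cc1c[nH]c(CCc2ccc(-c3csnn3)cc2)n1` gives 11 nM. Compound 3 `CCC(C)(C)Cc1c[nH]c(CCc2ccc(-c3cnsc3)cc2)n1` gives 6.9 nM, the lowest of the three numbers: its nearest neighbour is compound 2 and its furthest is compound 1. Among the measured steps, a 5.2-fold lower number from compound 1 to compound 2 (0.71 log units; beyond the scatter) and an 8.3-fold lower number from compound 1 to compound 3 (0.92 log units; beyond the scatter), whereas a 1.6-fold lower number from compound 2 to compound 3 (0.20 log units; within the scatter).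

Compound 4 `CCC(C)(C)Cc1c[nH]c(CCc2ccc(-c3ccns3)cc2)n1` is not yet measured; the change from compound 3 is 1,2-thiazol-5-yl in place of 1,2-thiazol-4-yl on an aromatic carbon. Within the data shown here, no measured step exchanges one 1,2-thiazolyl for another. The closest comparison is the step from compound 2 to compound 3, between two five-membered aromatic groups, which stays within the scatter. For this assay the expectation is a step of no more than the scatter, estimated as a 1.3-fold higher number from compound 3 to compound 4 (0.12 log units; within the scatter). Compound 4 is therefore expected at 9 nM, with a range from 4 nM to 25 nM.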

Compound 4, half-maximal effective concentration: 3.1 nM
The estimate for compound 4 lay 2.9-fold (0.46 log units) above the measured number; measured number below the stated range.
By their numbers in this assay, from the lowest: compound 4; then compounds 3 and 2 (each within the scatter of the next); then compound 1.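

Exchanging 1,2-thiazol-4-yl for 1,2-thiazol-5-yl leaves the atoms of the group unchanged and alters only how the ring is joined, yet it gives a step beyond the scatter (a 2.2-fold lower number from compound 3 to compound 4 (0.35 log units; beyond the scatter)) in this assay (this assay), so the attachment of the ring counts at this position and not only its composition. Among these compounds, the 1,2-thiazol-5-yl group also separates clearly from the other two groups (a 3.5-fold lower number from compound 2 to compound 4 (0.55 log units; beyond the scatter); an 18-fold lower number from compound 1 to compound 4 (1.26 log units; beyond the scatter)), and the second of these is the only large step. No supporting data bear on why the two ring attachments differ.

Open, as far as these compounds go, is whether 1,2-thiazol-3-yl, 1,3-thiazol-2-yl or a pyridine ring would give a lower or higher number at this position. Also open, from the compounds shown here alone, is whether a methyl group on the 1,2-thiazol-5-yl ring would be accepted.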